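Swapping Chloro for Methyl in Compound 1

A few compounds are considered here, and "the series" means these few. Any claim that something is new, unique, unknown or untested is made for them only; others in the source may bear on it.

Measured in a physicochemical assay for lipophilicity, read by HPLC, at pH 7.4; a lower number here means a more polar compound, a higher number a more lipophilic compound:
Compound 1 `Cc1ccccc1C(=O)Nc1cc(Cl)ccn1`: 3.4
Compound 2 `Cc1c(F)cccc1C(=O)Nc1cc(Cl)ccn1`: 2.3

Compound 1 holds the higher of these two numbers. Compound 3 `Cc1ccnc(NC(=O)c2ccccc2C)c1`, not yet measured, differs from it by methyl in place of chloro on an aromatic carbon. Among the measured compounds shown here, the only measured step is a number 1.10 log units lower from compound 1 to compound 2 (beyond the scatter), with fluoro in place of hydrogen on an aromatic carbon. That large step involves a different swap, so it gives no direct guide to this one and mainly argues for a wide range. In this assay, a small downward step, not beyond the scatter, is expected. The estimated step is a number 0.30 log units lower from compound 1 to compound 3 (within the scatter). For compound 3 the expected value is 3.1, with an estimated range of 2.6 to 3.5.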

Compound 3, distribution coefficient: 2.8
Beside the measured number, compound 3's estimate is 0.30 log units above it; the range from low to high includes it.
By their numbers in this assay, from the lowest: compound 2; then compound 3; then compound 1.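

Among the compounds shown here, the swap of chloro for methyl, on the aromatic carbon opposite the ring nitrogen, gives a number 0.60 log units lower from compound 1 to compound 3 (beyond the scatter) in this assay and is the first measured change at this position. Both groups count one heavy atom and no hydrogen-bond donors or acceptors, yet the number still moves beyond the scatter. Nothing measured here accounts for this step.

The compounds shown leave open how an amine, a methoxy group or a longer chain would read at this position. They also leave open whether the same swap gives a similar step with the fluoro of compound 2 present.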